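The compounds below may be only part of what the source reports. "The series", "measured", "known", "first", "only" and "open" are said of these compounds alone.

Compound 1 `Cc1ccc(/C=N/NC(=O)COc2ccc3c(C)cc(=O)oc3c2)o1`: 3190 nM
Compound 2 `Cc1cc(=O)oc2cc(OCC(=O)NNCc3ccccc3)ccc12`: 1240 nM

For the measured compounds named here, in a functional assay on MCF7 cells (Homo sapiens) for inhibition, read by MTT assay, with a stated time of 3 days (a lower number here means a stronger inhibitor, a higher number a weaker inhibitor), compound 2 gives 1240 nM, the lower of the two numbers so far, which makes it the stronger inhibitor of the pair. The next structure, compound 3 `Cc1cc(=O)oc2cc(OCC(=O)NNC(=O)c3ccccc3)ccc12`, keeps the core of compound 2 but carries benzoyl in place of benzyl on an amine nitrogen. Going by the values given here, only one measured step offers any guide: a 2.6-fold lower number from compound 1 to compound 2 (0.41 log units; beyond the scatter). Among the compounds with values here, that modest step, beyond the scatter, came from swapping a group on an amide-type nitrogen, and no measured compound yet carries this benzoyl group. The evidence is therefore thin, and the direction is a cautious guess. A modest move toward a weaker inhibitor in this assay is expected, estimated as a 1.8-fold higher number from compound 2 to compound 3 (0.25 log units; within the scatter). For compound 3 the estimated value is 2200 nM, with an expected range from 700 nM to 7000 nM.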

Compound 3, half-maximal inhibitory concentration: 7890 nM
Estimate against measurement, compound 3: 3.6-fold (0.55 log units) below; measured number outside the range, above it.
By their numbers in this assay, from the lowest: compound 2; then compound 1; then compound 3.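

In this assay, this amine nitrogen proves sensitive to a small edit: benzoyl in place of benzyl moves the number up (a 6.4-fold higher number from compound 2 to compound 3 (0.80 log units; beyond the scatter)). Both groups carry the same six-membered aromatic ring of carbon only, so the two compounds differ only by the carbonyl that benzoyl brings, with its one hydrogen-bond acceptor. The earlier step exchanged one ring for another, whereas this one shows that a clear change in the number can arise with the ring left the same.

Nothing among the data shown explains why the carbonyl goes with a weaker inhibitor here. Also open, as far as these compounds go, is how this nitrogen would respond to a group such as acetyl, or to a longer chain ending in an amine or a carboxylic acid.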